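Swapping 2-methoxyphenyl for 4-chlorophenyl in compound 2

This account rests on a few compounds, and the source may have more. Where it says the series, first, only, none or still open, it means among the compounds named here.

- compound 1 `Cc1noc2c(C(c3ccccc3)c3c(-c4ccccc4)c[n+]([O-])c4c(C)noc34)c(-c3ccccc3)c[n+]([O-])c12`: 26.6 ug/mL
- compound 2 `COc1ccccc1C(c1c(-c2ccccc2)c[n+]([O-])c2c(C)noc12)c1c(-c2ccccc2)c[n+]([O-])c2c(C)noc12`: 51.9 ug/mL
- compound 3 `Cc1noc2c(C(c3ccccc3Cl)c3c(-c4ccccc4)c[n+]([O-])c4c(C)noc34)c(-c3ccccc3)c[n+]([O-])c12`: 70.4 ug/mL

In a functional assay on Ehrlich cells (Homo sapiens) for cytotoxicity, read by MTT assay, with a stated time of 48 h (on this read-out lower numbers stand for stronger inhibition and higher numbers for weaker inhibition), compound 2 gives 51.9 ug/mL, which sits within the scatter of both other values: a 2.0-fold higher number from compound 1 to compound 2 (0.29 log units; within the scatter), and a 1.4-fold higher number from compound 2 to compound 3 (0.13 log units; within the scatter). Only the outer pair is separated, with a 2.6-fold higher number from compound 1 to compound 3 (0.42 log units; beyond the scatter).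

Compound 4 `Cc1noc2c(C(c3ccc(Cl)cc3)c3c(-c4ccccc4)c[n+]([O-])c4c(C)noc34)c(-c3ccccc3)c[n+]([O-])c12` has not been measured. The change is 4-chlorophenyl in place of 2-methoxyphenyl on a saturated chain carbon bound to two aromatic carbons, in words 4-chlorophenyl in place of 2-methoxyphenyl on a saturated chain carbon bound to two aromatic carbons. The nearest guide is chloro in place of methoxy, a 1.4-fold higher number from compound 2 to compound 3 (0.13 log units; within the scatter). Chloro in place of hydrogen gave a 2.6-fold higher number from compound 1 to compound 3 (0.42 log units; beyond the scatter). Going by the values given here, no measured compound carries the 4-chlorophenyl group, so no step beyond the scatter is expected in this assay. The estimated step is a 1.0-fold lower number from compound 2 to compound 4 (0.02 log units; within the scatter). For compound 4 the estimate is 50 ug/mL, with an expected range of 20 ug/mL to 110 ug/mL.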

Compound 4, half-maximal inhibitory concentration: 60.6 ug/mL
Estimate against measurement, compound 4: 1.2-fold (0.08 log units) below; the measured number falls inside the stated range.
By their numbers in this assay, from the lowest: compounds 1, 2, 4 and 3 (each within the scatter of the next, the first and the last beyond it).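

On the saturated chain carbon bound to two aromatic carbons, 4-chlorophenyl and 2-methoxyphenyl cannot be told apart in this assay (a 1.2-fold higher number from compound 2 to compound 4 (0.07 log units; within the scatter)). Swapping 2-chlorophenyl for 4-chlorophenyl also stays within the scatter (a 1.2-fold lower number from compound 3 to compound 4 (0.07 log units; within the scatter)), so the place of the chloro on this ring makes no readable difference here. Chloro in place of hydrogen, by contrast, gives a modest step beyond the scatter (a 2.3-fold higher number from compound 1 to compound 4 (0.36 log units; beyond the scatter)), just as it did for compound 3.

Nothing measured here explains these numbers. Going by these compounds, whether an amine or a carboxylic acid on this phenyl ring would give a number lower than that of compound 1 remains open.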